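Removing a nitro group from a nitrofuran amide

The compounds below may be only part of what the source reports. "The series", "measured", "known", "first", "only" and "open" are said of these compounds alone.

Three compounds sharing one core were tested in an ADME assay on MRC5 cells (Homo sapiens) for cytotoxicity; a higher number here means a weaker inhibitor, a lower number a stronger inhibitor. Compound 1 `COc1ccc(Cn2cc(CNC(=O)c3ccc([N+](=O)[O-])o3)nn2)cc1[N+](=O)[O-]` gives 198000 nM, the second highest of the three numbers and within the scatter of both compound 3 `O=C(NCc1cn(Cc2ccc([N+](=O)[O-])cc2)nn1)c1ccc([N+](=O)[O-])o1` at 213000 nM and compound 2 `COc1cc(Cn2cc(CNC(=O)c3ccc([N+](=O)[O-])o3)nn2)ccc1O` at 182000 nM. For the measured compounds named here, the single measured step, a 1.2-fold higher number from compound 2 to compound 3 (0.07 log units; within the scatter), concerns a different exchange and stays within the scatter. Compound 4 `COc1ccc(Cn2cc(CNC(=O)c3ccc([N+](=O)[O-])o3)nn2)cc1` differs from compound 1 by hydrogen in place of nitro on an aromatic carbon. Going by the values given here, no measured step bears directly on this change; the one step available shows that swapping the group on that part of the molecule left this assay unchanged, so no step beyond the scatter is expected here. For compound 4 the estimated value is 200000 nM, ranging from 100000 nM to 400000 nM, an expected step of a 1.0-fold higher number from compound 1 to compound 4 (0.00 log units; within the scatter).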

Compound 4, half-maximal inhibitory concentration: 146000 nM
Compound 4: middle estimate off by 1.4-fold (0.14 log units), on the high side; the measured number falls inside the stated range.
By their numbers in this assay, from the lowest: compounds 4, 2, 1 and 3 (each within the scatter of the next).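

In this assay, for the compounds shown here, hydrogen in place of nitro on the aromatic carbon ortho to a methoxy group gives a 1.4-fold lower number from compound 1 to compound 4 (0.13 log units; within the scatter) and so provides the first measured step at this position. The two other comparisons with compound 4 also stay within the scatter, with a 1.5-fold lower number from compound 3 to compound 4 (0.16 log units; within the scatter) and a 1.2-fold lower number from compound 2 to compound 4 (0.10 log units; within the scatter) as their steps. No measured evidence accounts for these numbers. As far as these compounds go, whether an amine or a carboxylic acid on this carbon would give a step beyond the scatter remains open.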